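A few compounds are considered here, and "the series" means these few. Any claim that something is new, unique, unknown or untested is made for them only; others in the source may bear on it.

Measured in an ADME assay on Huh-7 cells (Homo sapiens) for cytotoxicity, with a stated time of 72 h; on this read-out higher numbers stand for lower toxicity in this test and lower numbers for higher toxicity in this test:
- Compound 1 `CC(C)CCn1nc(-c2cccs2)c(O)c(C2=NS(=O)(=O)c3cc(S(=O)(=O)N(C)C)ccc3N2)c1=O`: "not determined" (no result reported)
- Compound 2 `CC(C)CCn1nc(-c2cncs2)c(O)c(C2=NS(=O)(=O)c3cc(NS(C)(=O)=O)ccc3N2)c1=O`: > 33000 nM

For the measured compounds named here, compound 1 offers no result to compare, which leaves compound 2 as the only guide. In this assay compound 2 gives > 33000 nM. From the compounds shown here alone, that value is a limit of the assay and not a number, so the true position of compound 2 remains unknown.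

Compound 3 `CC(C)CCn1nc(-c2ccn(C)c2)c(O)c(C2=NS(=O)(=O)c3cc(NS(C)(=O)=O)ccc3N2)c1=O` has not yet been measured. It keeps the rest of compound 2 and changes one group, with 1-methyl-1H-pyrrol-3-yl in place of 1,3-thiazol-5-yl on an aromatic carbon. The swapped ring sits next to the ring nitrogen and ortho to a hydroxy group.

Going by the values given here, no measured pair of compounds shows what a swap of this kind does in this assay. The expectation is therefore modest: no change beyond the usual scatter, and no clear direction. The expected step is an at least 1.1-fold lower number from compound 2 to compound 3 (0.04 log units; that floor lies within the scatter), an estimate rather than a measurement. For compound 3 the estimated value is 30000 nM, with an expected range of 12000 nM to 50000 nM.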

Compound 3, half-maximal cytotoxic concentration: > 1000 nM
Compound 3 was reported as a limit (the forecaster's own chance of this, stated with the estimate: 70%); the middle value lies beyond the limit too.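

For the compounds shown here, compound 2 and compound 3 are both reported only as limits of the assay, not as numbers, and no step between them can be read in this assay. Still open, from the compounds shown here alone, is where the true values of these two compounds lie, and whether 1-methyl-1H-pyrrol-3-yl in place of 1,3-thiazol-5-yl changes the read-out at all, or in which direction.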